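A few compounds are considered here, and "the series" means these few. Any claim that something is new, unique, unknown or untested is made for them only; others in the source may bear on it.

Working notes on the series around the shared core of compound 1 `Cc1n[nH]c(C(=O)O)c1Cc1ccc(Oc2ccccc2)cc1`. In an assay on isolated protein for inhibition of 2-Hydroxyacid oxidase 2 (Homo sapiens), tested at 1 uM (a lower number here means a weaker effect, a higher number a stronger effect of the compound at the concentration tested), compound 1 gives 10%, which is the top number of the three measured, but neither neighbour lies beyond the scatter from it. Within the data shown here, compound 2 `Cc1n[nH]c(C(=O)O)c1Cc1cccc(-c2ccccc2F)c1` gives 5% in this assay, and compound 3 `Cc1n[nH]c(C(=O)O)c1Cc1cccc(C(F)(F)F)c1` gives 5%; the only step between compounds that differ in one place, no change at the digits printed from compound 2 to compound 3 (within the scatter), shows no movement. Compound 4 `Cc1n[nH]c(C(=O)O)c1Cc1ccc(C(N)=O)cc1` is not yet measured in this assay. It differs from compound 1 as follows: carbamoyl in place of phenoxy on an aromatic carbon. Among the measured compounds shown here, no measured step exchanges a carbamoyl for a phenoxy, so nothing in the data bears directly on this change; the one step that exists swaps one group on the same kind of aromatic carbon for another and leaves the read-out unchanged within the scatter. All three numbers sit low and close together. Compound 4 is therefore expected to stay in the same low band, with a step of a number 3 percentage points lower from compound 1 to compound 4 (within the scatter) that does not exceed the scatter. The estimate for compound 4 is 7%, within 0% to 20%.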

Compound 4, a percentage reported as inhibition, at one concentration (the size of the read-out at that concentration, not a potency): 0%
Beside the measured number, compound 4's estimate is 7 percentage points above it; the measured number falls inside the stated range.
By their numbers in this assay, from the lowest: compounds 4, 2, 3 and 1 (each within the scatter of the next).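

In this assay, among these compounds, the step of a number 10 percentage points lower from compound 1 to compound 4 (within the scatter) is the first at the aromatic carbon para to a large group. Phenoxy leaves with its six-membered aromatic ring, and the smaller carbamoyl enters with no ring and a hydrogen-bond donor, yet this exchange stays within the scatter, so neither the loss of that ring nor the gain of that donor gives a readable change at this place. No measurement here offers an explanation for this result.

With the four compounds shown, it remains open whether any group at this place can lift the read-out clear of the scatter. An amine, a carboxylic acid or a longer chain on the same aromatic carbon would test this.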